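Ring size change on two cores in mouse liver microsomes

The compounds below may be only part of what the source reports. "The series", "measured", "known", "first", "only" and "open" are said of these compounds alone.

Two pairs of compounds share one structural change, made on two different cores. Compound 1 `Nc1nc2cc(N3CCCC3)ccc2cc1-c1cc(Cl)cc(Cl)c1` carries a pyrrolidin-1-yl group, and compound 2 `Nc1nc2cc(N3CCCCC3)ccc2cc1-c1cc(Cl)cc(Cl)c1` carries a piperidin-1-yl group at the same position; the change is piperidin-1-yl in place of pyrrolidin-1-yl on an aromatic carbon. In an ADME assay on microsomes from liver (Mus musculus) for metabolic stability, read by HPLC, with a stated time of 4 h (a higher number here means that the compound lasts longer, a lower number that the compound disappears faster), compound 1 gives 0.2 h. In this assay compound 2 gives 0.1 h. The measured size of this change on the first core is a 2.0-fold lower number from compound 1 to compound 2 (0.30 log units; within the scatter).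

Compound 3 `Cn1cc(-c2cc3ccc(N4CCCC4)cc3nc2N)c2ccccc21` has a different core; the difference between the two cores is not broken down here. In this assay compound 3 gives < 0.1 h, which is a limit of the assay and not a number. For the measured compounds named here, compound 4 `Cn1cc(-c2cc3ccc(N4CCCCC4)cc3nc2N)c2ccccc21` has not yet been measured and differs from compound 3 by piperidin-1-yl in place of pyrrolidin-1-yl on an aromatic carbon, which is the same change as the one between compound 1 and compound 2.

The step from compound 3 to compound 4 is expected to be a step that the limit leaves unreadable from compound 3 to compound 4, set beside the measured step of a 2.0-fold lower number from compound 1 to compound 2 (0.30 log units; within the scatter). This expectation rests on compound 1 and compound 2, whose step a 2.0-fold lower number from compound 1 to compound 2 (0.30 log units; within the scatter) stays within the scatter. It also rests on compound 3, which sits at the limit of < 0.1 h in this assay, at which 1 of the 3 values shown sits. Compound 4 is therefore expected to give about 0.05 h in this assay, with a range from 0.02 h to 0.12 h, and it may well come back as a limit only.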

Compound 4, half-life: 0.8 h
The estimate for compound 4 lay 16-fold (1.20 log units) below the measured number; the measured number lies above the stated range.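

On the second core, piperidin-1-yl in place of pyrrolidin-1-yl gives an at least 8.0-fold higher number from compound 3 to compound 4 (0.90 log units; beyond the scatter) in this assay, so the step read on the first core did not foretell the step on the second: the same change on two cores in this assay, a 2.0-fold lower number (0.30 log units; within the scatter) from compound 1 to compound 2 and an at least 8.0-fold higher number (0.90 log units; beyond the scatter) from compound 3 to compound 4, at least 16-fold (1.20 log units) apart, beyond the scatter of two such steps

For compound 3, the starting value is a limit of the assay and not a number: the limit of < 0.1 h in this assay, at which 1 of the 4 values shown sits.

This shows that, across these two cores, the change cannot be carried over as a fixed amount, since the result on one core gave no safe guide to the result on the other, but two pairs cannot explain why the cores part ways, and they give no rule for any further core in the series.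

The compounds shown leave open how other rings at this position, such as morpholin-4-yl or azepan-1-yl, would behave on each of the two cores in this assay, which would help tell whether ring size itself matters or only piperidin-1-yl. Also open, on these data alone, is whether piperidin-1-yl on a third core would follow compound 4 or compound 2.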